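The compounds below may be only part of what the source reports. "The series", "measured", "known", "first", "only" and "open" are said of these compounds alone.

Among the compounds with values here, compound 2 `Nc1cc(N)c2nc(-c3ccccc3)c(NCc3ccc(F)cc3)nc2c1` gives 20000 nM in a functional assay on SNB-19 cells (Homo sapiens) for inhibition, read by sulforhodamine B assay, with a stated time of 48 h (a lower number here means a stronger inhibitor of growth, a higher number a weaker inhibitor of growth), the only number in the set. Compound 1 `COc1ccc(CNc2nc3cc(N)cc(N)c3nc2-c2ccccc2)cc1OC` reaches only a limit in this assay, < 100000 nM. The step that the limit leaves unreadable from compound 1 to compound 2 thus stays unreadable, since one end sits at the limit of < 100000 nM in this assay, at which 1 of the 2 values shown sits. Compound 3 `COc1ccc(CNc2nc3cc(N)cc(N)c3nc2-c2ccccc2)cc1` differs from compound 2 by methoxy in place of fluoro on an aromatic carbon. No measured step bears on this change, as the single step shown carries no size. Compound 3 is therefore expected near compound 2, the step of no change at the digits printed from compound 2 to compound 3 (within the scatter) staying within scatter. The estimate for compound 3 is 20000 nM, with a range from 6000 nM to 70000 nM.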

Compound 3, concentration for total growth inhibition: < 100000 nM
Compound 3 gave a limit, no number (the forecaster's own chance of this, stated with the estimate: 20%); the middle value does not contradict the limit.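

Within the data shown here, no step from compound 1 or compound 2 to compound 3 can be read: the limit of < 100000 nM in this assay, at which 2 of the 3 values shown sit. The compounds shown leave open how far compound 1 and compound 3 actually stand from compound 2, and so whether methoxy in place of fluoro changes growth inhibition at all.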